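A few compounds are considered here, and "the series" means these few. Any claim that something is new, unique, unknown or untested is made for them only; others in the source may bear on it.

In an ADME assay on HEK293 cells (Homo sapiens) for cytotoxicity, read by MTT assay, with a stated time of 72 h (a higher number here means a weaker inhibitor, a lower number a stronger inhibitor), compound 1 `COc1cccc(C(=O)N2CCN(CC(=O)N3CCN(CCCc4c[nH]c5ccc(F)cc45)CC3)CC2)c1` gives 87100 nM, compound 2 `O=C(CN1CCN(C(=O)c2cccc(F)c2)CC1)N1CCN(CCCc2c[nH]c3ccc(F)cc23)CC1` gives 83000 nM and compound 3 `O=C(CN1CCN(C(=O)c2ccccc2Br)CC1)N1CCN(CCCc2c[nH]c3ccc(F)cc23)CC1` gives 77100 nM. Compound 1 therefore cannot be separated from either neighbour. The next analogue, compound 4 `COc1cccc(C(=O)N2CCN(CC(=O)N3CCN(CCCc4c[nH]c5ccc(OC)cc45)CC3)CC2)c1`, keeps the 3-methoxyphenyl group of compound 1 and differs at the other end of the molecule: methoxy in place of fluoro on an aromatic carbon. This is methoxy in place of fluoro on an aromatic carbon, turning 5-fluoro-1H-indol-3-yl into 5-methoxy-1H-indol-3-yl. Among the compounds with values here, no measured compound varies this group, so the evidence is indirect. Within the data shown here, the closest precedent exchanges the same two groups at another aromatic carbon, in the opposite direction, and gives a 1.0-fold lower number from compound 1 to compound 2 (0.02 log units; within the scatter). The remaining changes, both on the group attached to the carbonyl, give a 1.1-fold lower number from compound 1 to compound 3 (0.05 log units; within the scatter) and a 1.1-fold lower number from compound 2 to compound 3 (0.03 log units; within the scatter). On these small steps, no shift beyond the scatter is expected in this assay, and the expected step is a 1.1-fold lower number from compound 1 to compound 4 (0.04 log units; within the scatter). For compound 4 the estimated value is 80000 nM, with an expected range of 40000 nM to 150000 nM.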

Compound 4, half-maximal inhibitory concentration: > 200000 nM
Compound 4: only a limit was reported; the forecaster's own chance of this, stated with the estimate: 15%; middle value at least 2.5-fold (0.39 log units) away from the limit.
By their numbers in this assay, from the lowest: compounds 3, 2 and 1 (each within the scatter of the next). At a limit, above all of these: compound 4.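

Within the data shown here, exchanging 5-fluoro-1H-indol-3-yl for 5-methoxy-1H-indol-3-yl gives the only step beyond the scatter in this assay: an at least 2.2-fold higher number from compound 1 to compound 4 (0.36 log units; beyond the scatter). The steps among compounds 1, 2 and 3, all on the group attached to the carbonyl, stay within the scatter, so this aromatic carbon, para to a fused ring, is the only place shown where a change moves the number. Compound 4 gives > 200000 nM, which is a limit and not a number: the limit of > 200000 nM in this assay, at which 1 of the 4 values shown sits.

On these data alone, this reading rests on a single pair, so it stays open whether other groups on this carbon, such as a hydroxyl, a chlorine or an amine, would behave like methoxy or like fluoro. Also open, as far as these compounds go, is whether the same exchange gives a similar step with the 3-fluorophenyl of compound 2 or the 2-bromophenyl of compound 3 on the carbonyl.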